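The source may hold more compounds than are shown below. What is called first, only, known or untested is meant among the compounds shown, and "the series" means these compounds.

Measured so far in a functional assay on MDA-MB-231 cells (Homo sapiens) for inhibition, read by sulforhodamine B assay, with a stated time of 48 h; a lower number here means a stronger inhibitor of growth, a higher number a weaker inhibitor of growth:
Compound 1 `COc1ccc2c(c1)NC(=O)CN2c1nc(OCC2CC2)nc2ccccc12` gives 45.2 nM
Compound 2 `COc1ccc2c(c1)NC(=O)CN2c1nc(N2CCCC2)nc2ccccc12` gives 80.1 nM

Only these two numbers exist, and the step between them reads a 1.8-fold higher number from compound 1 to compound 2 (0.25 log units; within the scatter) here, so compound 2 cannot be separated from compound 1 on the data available.

Compound 3 `COc1ccc2c(c1)NC(=O)CN2c1nc(N2CC(OC)C2)nc2ccccc12` differs from compound 2 in one group, as counted here: 3-methoxyazetidin-1-yl in place of pyrrolidin-1-yl on an aromatic carbon (in words, 3-methoxyazetidin-1-yl in place of pyrrolidin-1-yl on an aromatic carbon, between two ring nitrogen atoms).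

Within the data shown here, the same carbon also carried the only measured change, a 1.8-fold higher number from compound 1 to compound 2 (0.25 log units; within the scatter) in size, so swapping the group there has so far moved this assay very little. Among the measured compounds shown here, no measured compound carries a four-membered non-aromatic ring, which makes this single step thin evidence, and it offers no direction. A shift beyond the scatter is therefore not expected, though the range must stay wide. The expected change is a 1.1-fold lower number from compound 2 to compound 3 (0.06 log units; within the scatter) on this reasoning. For compound 3 the estimate is 70 nM and the expected range runs from 20 nM to 250 nM once measured.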

Compound 3, concentration for 50% growth inhibition: 53.1 nM
Compound 3: middle estimate off by 1.3-fold (0.12 log units), on the high side; measured number inside the range.
By their numbers in this assay, from the lowest: compounds 1, 3 and 2 (each within the scatter of the next).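

In this assay, putting 3-methoxyazetidin-1-yl on the aromatic carbon between two ring nitrogen atoms gives a 1.5-fold lower number from compound 2 to compound 3 (0.18 log units; within the scatter) and, set against the cyclopropylmethoxy group, a 1.2-fold higher number from compound 1 to compound 3 (0.07 log units; within the scatter) in the same read-out. Among these compounds, this is the first test of a four-membered non-aromatic ring at this position, and the first of a group there with both a ring nitrogen and an oxygen atom: the five-membered ring has given way to a four-membered one, and the count of hydrogen-bond acceptors in the group has risen from 1 to 2, yet neither step leaves the scatter, so all three groups remain indistinguishable here. No supporting measurement is available to say what lies behind this flat picture.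

On these data alone, it remains open whether a piperazin-1-yl ring, a carboxylic acid or a longer alkyl chain on this same carbon would move the number beyond the scatter. As far as these compounds go, all three compounds also share the rest of their structure, so the contribution of the methoxy group and the carbonyl on the shared core remains unknown.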